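A few compounds are considered here, and "the series" means these few. Any claim that something is new, unique, unknown or untested is made for them only; others in the source may bear on it.

Values from a functional assay on P388 cells (Mus musculus) for cytotoxicity (on this read-out higher numbers stand for weaker inhibition and lower numbers for stronger inhibition), for the measured compounds

- compound 1 `COc1ccc(C[C@H]2C(=O)N[C@@H](C)C(=O)N(C)[C@H]3Cc4ccc(cc4)Oc4cc(ccc4OC)C[C@@H](C(=O)N[C@H](C)C(=O)N[C@@H](CSC(C)=O)C(=O)N2C)N(C)C3=O)cc1` gives 9.77 nM
- compound 2 `COc1ccc(C[C@H]2C(=O)N[C@@H](C)C(=O)N(C)[C@H]3Cc4ccc(cc4)Oc4cc(ccc4OC)C[C@@H](C(=O)N[C@H](C)C(=O)NC4(SCCS4)C(=O)N2C)N(C)C3=O)cc1` gives 631 nM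
- compound 3 `COc1ccc(C[C@H]2C(=O)N[C@@H](C)C(=O)N(C)[C@H]3Cc4ccc(cc4)Oc4cc(ccc4OC)C[C@@H](C(=O)N[C@H](C)C(=O)N[C@@H](CC=O)C(=O)N2C)N(C)C3=O)cc1` gives 33.9 nM

Compound 3 stands in the middle of these three numbers, with compound 1 lower and compound 2 much higher. The next compound is compound 4 `COc1ccc(C[C@H]2C(=O)N[C@@H](C)C(=O)N(C)[C@H]3Cc4ccc(cc4)Oc4cc(ccc4OC)C[C@@H](C(=O)N[C@H](C)C(=O)N[C@@H](CCO)C(=O)N2C)N(C)C3=O)cc1` and it differs from compound 3 in one place. Hydroxymethyl stands in place of formyl on a saturated chain carbon bound to a saturated ring carbon, and the count of that change reads hydroxymethyl in place of formyl on a saturated chain carbon bound to a saturated ring carbon in full.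

Among the measured compounds shown here, the one measured step that bears on this is a 3.5-fold higher number from compound 1 to compound 3 (0.54 log units; beyond the scatter) and it was modest, with formyl replacing acetylsulfanyl on that same carbon. For the measured compounds named here, no measured compound carries hydroxymethyl, so the direction remains uncertain. A modest step of similar size towards a higher number in this assay is the working expectation. The expected step is a 1.8-fold higher number from compound 3 to compound 4 (0.25 log units; within the scatter) as an estimate. For compound 4 the estimated value is 60 nM with an expected range from 15 nM to 240 nM as its limits.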

Compound 4, half-maximal inhibitory concentration: 60.3 nM
Estimate against measurement, compound 4: 1.0-fold (0.00 log units) below; the measured number falls inside the stated range.
By their numbers in this assay, from the lowest: compound 1; then compounds 3 and 4 (each within the scatter of the next); then compound 2.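

In this assay, hydroxymethyl in place of formyl on this saturated chain carbon gives a 1.8-fold higher number from compound 3 to compound 4 (0.25 log units; within the scatter), so at this position the change from formyl to hydroxymethyl, which brings in a hydrogen-bond donor and removes a double bond, does not move the number beyond the usual scatter. Hydroxymethyl in place of acetylsulfanyl gives a 6.2-fold higher number from compound 1 to compound 4 (0.79 log units; beyond the scatter), which means that compound 3 and compound 4 read alike and that neither matches the number of compound 1, the acetylsulfanyl compound. Nothing available explains either step.

The compounds shown do not tell whether an amine, a carboxylic acid or a longer chain on this carbon would stay close to compound 3 and compound 4 or come closer to compound 1. They also leave open how a free sulfanyl group would compare with acetylsulfanyl here.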